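Halophenyl Amides Against Glioma Cell Growth

This account rests on a few compounds, and the source may have more. Where it says the series, first, only, none or still open, it means among the compounds named here.

Compound 1 `COc1ccc(NC(=O)CNc2ccc(C(=O)Nc3ccccc3N)cc2)cc1` and compound 2 `Nc1ccccc1NC(=O)CCCNCC(=O)Nc1ccc(Br)cc1` were examined in a functional assay on U-251 cells (Homo sapiens) for inhibition, read by MTT assay, with a stated time of 2 days; on this read-out lower numbers stand for stronger inhibition of growth and higher numbers for weaker inhibition of growth. Compound 1 reached only the limit of the assay, giving > 100000 nM, which is not a number. Among the compounds with values here, compound 2 gives 80000 nM in this assay, the only number among the two values shown. The other value sits at the limit of > 100000 nM in this assay, at which 1 of the 2 values shown sits. Compound 3 `Nc1ccccc1NC(=O)CCCNCC(=O)Nc1ccccc1Cl` carries 2-chlorophenyl in place of 4-bromophenyl on an amide-type nitrogen. Within the data shown here, no step between measured compounds is known here, so the change is expected to shift the value no further than the scatter, in no set direction. Compound 3 is therefore estimated at 80000 nM, between 35000 nM and 180000 nM. The expected step is no change at the digits printed from compound 2 to compound 3 (within the scatter).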

Compound 3, concentration for total growth inhibition: > 100000 nM
Compound 3: a limit, no number; the forecaster's own chance of this, stated with the estimate: 35%; middle value at least 1.2-fold (0.09 log units) away from the limit.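

Replacing 4-bromophenyl with 2-chlorophenyl on the amide-type nitrogen gives, in this assay, an at least 1.2-fold higher number from compound 2 to compound 3 (0.09 log units; that floor lies within the scatter), so the floor of this step does not separate the two halophenyl groups. Compound 3 gives > 100000 nM, which is a limit of the assay and not a number. Compound 2 now stands as the only compound shown with a number: the limit of > 100000 nM in this assay, at which 2 of the 3 values shown sit.

On these data alone, the halogen and its place on the ring changed together, so their separate contributions remain open. A 4-chlorophenyl group on the same nitrogen would separate the two changes.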